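A few compounds are considered here, and "the series" means these few. Any claim that something is new, unique, unknown or untested is made for them only; others in the source may bear on it.

Measured compounds:
- compound 1, `COC(=O)Nc1cc(-c2ccc(OC[C@@](C)(N)CC(C)C)c(C)c2)ccn1`: 0.8 nM
- compound 2, `CC(=O)Nc1cc(-c2ccc(OC[C@@H](N)CC(C)C)c(F)c2)ccn1`: 1.6 nM
- compound 3, `CC(=O)Nc1cc(-c2ccc(OC[C@@H](N)CC(C)C)c(Cl)c2)ccn1`: 0.2 nM

In an assay on HEK293F cells for inhibition of AP2-associated protein kinase 1 (Homo sapiens), read by Western blot, with a stated time of 3 h (a lower number here means a stronger inhibitor, a higher number a weaker inhibitor), compound 3 gives the lowest number of the three, with compound 1 nearest and compound 2 furthest away, and both of those gaps fall beyond the scatter. So compound 3 is the strongest inhibitor among the measured compounds.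

Compound 4, `CC(=O)Nc1cc(-c2ccc(OC[C@@H](N)CC(C)C)cc2)ccn1`, has not yet been measured. It differs from compound 3 in one place: hydrogen in place of chloro on an aromatic carbon. The change strips the halogen from the ring entirely.

For the measured compounds named here, the only single-point step measured so far at that ring position is an 8.0-fold lower number from compound 2 to compound 3 (0.90 log units; beyond the scatter). Compound 1 also carries a substituent at that position, but it differs from compound 3 in more than one place, so its value only shows what that whole molecule does. Since exchanging fluoro for chloro lowered the number in this assay by a clear margin, removing the halogen altogether is expected to move the number back up, most likely to about where compound 2 sits or somewhat above it, rather than to leave it unchanged.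

For compound 4 in this assay the expected value is therefore 2 nM, with a range from 0.6 nM to 6 nM, which would mean a step of a 10-fold higher number from compound 3 to compound 4 (1.00 log units; beyond the scatter).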

Compound 4, half-maximal inhibitory concentration: 8.1 nM
Compound 4: middle estimate off by 4.1-fold (0.61 log units), on the low side; the measured number lies above the stated range.
By their numbers in this assay, from the lowest: compound 3; then compounds 1 and 2 (each within the scatter of the next); then compound 4.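

In this assay, the position ortho to the (2-amino-4-methylpentyl)oxy group now has a hydrogen reference, and losing the chloro costs far more than the earlier fluoro-to-chloro exchange suggested (a 41-fold higher number from compound 3 to compound 4 (1.61 log units; beyond the scatter)). Fluoro also lowers the number relative to hydrogen, seen here in reverse as its removal gives a smaller rise (a 5.1-fold higher number from compound 2 to compound 4 (0.70 log units; beyond the scatter)), so both halogens count at this position and neither compound 2 nor compound 3 owes its value to the shared core alone. Across compound 2, compound 3 and compound 4, the numbers fall in the order hydrogen, fluoro, chloro, with every step beyond the scatter, and nothing available explains that order.

The compounds shown leave open whether bromo, methoxy or a nitrile at this position would keep the number as low as chloro does, or whether the order seen with the halogens extends to them. Compound 1 carries a methyl there but differs from compound 3 in more than one place, so the effect of methyl alone cannot be read from it.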